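Thioether chain shortened on the shared core

A few compounds are considered here, and "the series" means these few. Any claim that something is new, unique, unknown or untested is made for them only; others in the source may bear on it.

Measured so far:
compound 1 `Cc1cc(N2CC[C@@H](C)[C@@H](N(C)c3ncnc4[nH]ccc34)C2)n2nc(SCC3CCCCC3)nc2n1`: 16300 nM
compound 2 `C[C@@H]1CCN(c2cc(-c3ccccc3)nc3ncnn23)C[C@@H]1N(C)c1ncnc2[nH]ccc12`: > 100000 nM

For the measured compounds named here, in a functional assay on BGC-823 cells (Homo sapiens) for inhibition, read by MTT assay, with a stated time of 72 h (on this read-out higher numbers stand for weaker inhibition and lower numbers for stronger inhibition), compound 1 gives 16300 nM, the only number recorded for the series. Compound 2 sits at the limit of > 100000 nM in this assay, at which 1 of the 2 values shown sits, a limit of the assay and not a number. Compound 3 `C=CCSc1nc2nc(C)cc(N3CC[C@@H](C)[C@@H](N(C)c4ncnc5[nH]ccc45)C3)n2n1` differs from compound 1 in vinyl in place of cyclohexyl on a saturated chain carbon bound to a sulfur. Going by the values given here, no step between measured compounds is available to anchor this change, so the expectation rests on compound 1 alone. A step of a 1.8-fold higher number from compound 1 to compound 3 (0.26 log units; within the scatter) toward weaker inhibition is expected, of modest size, with a fair chance that only a limit is returned. The estimate for compound 3 is 30000 nM, with a range from 8000 nM to 100000 nM.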

Compound 3, half-maximal inhibitory concentration: 40900 nM
The estimate for compound 3 lay 1.4-fold (0.13 log units) below the measured number; the measured number falls inside the stated range.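

In this assay, the position on a saturated chain carbon bound to a sulfur now has its first measured step: vinyl in place of cyclohexyl gives a 2.5-fold higher number from compound 1 to compound 3 (0.40 log units; beyond the scatter). The six-membered ring is not needed for a measurable number, as compound 3 still returns a value and not a limit. Compound 2 stands as a limit of the assay and not a number: the limit of > 100000 nM in this assay, at which 1 of the 3 values shown sits.

This single step cannot separate loss of the ring from shortening of the chain. From the compounds shown here alone, how a longer straight alkyl chain or a terminal amine would read at this position remains open.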